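Swapping the sulfonyl aryl group for a pyridin-2-yl ring

A few compounds are considered here, and "the series" means these few. Any claim that something is new, unique, unknown or untested is made for them only; others in the source may bear on it.

Of the compounds shown here, three sharing one core have been measured in a functional assay (trachea) for antagonist activity, with Cavia porcellus as the target; a lower number here means a less potent compound, a higher number a more potent compound, by a factor of ten per unit of this negative logarithm. Compound 1 `COc1cc(C(=O)NS(=O)(=O)c2ccc3ccccc3c2)ccc1Cn1ccc2ccc(NC(=O)CC3CCCC3)cc21` gives 8.3. Compound 2 `COc1cc(C(=O)NS(=O)(=O)c2ccccc2C)ccc1Cn1ccc2ccc(NC(=O)CC3CCCC3)cc21` gives 9.9. Compound 3 `COc1ccc(OC)c(S(=O)(=O)NC(=O)c2ccc(Cn3ccc4ccc(NC(=O)CC5CCCC5)cc43)c(OC)c2)c1` gives 9.1, the second highest of the three numbers: compound 1 lies a number 0.80 log units higher from compound 1 to compound 3 (beyond the scatter), and compound 2 lies a number 0.80 log units lower from compound 2 to compound 3 (beyond the scatter). All three differ only in the group on the sulfonyl sulfur, and that single place has moved the result by as much as a number 1.60 log units higher from compound 1 to compound 2 (beyond the scatter).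

Compound 4 `COc1cc(C(=O)NS(=O)(=O)c2ccccn2)ccc1Cn1ccc2ccc(NC(=O)CC3CCCC3)cc21` changes the same place: pyridin-2-yl in place of 2,5-dimethoxyphenyl on a sulfonyl sulfur. For the measured compounds named here, no measured step involves a pyridin-2-yl group, so the only guidance is that a smaller single ring on the sulfonyl sulfur, as in compound 2 and compound 3, has so far given higher numbers than the two-ring naphthalen-2-yl group of compound 1. The step from compound 3 to compound 4 is therefore expected to be small, a number 0.20 log units higher from compound 3 to compound 4 (within the scatter), with either direction possible. The estimate for compound 4 in this assay is 9.3, within a range from 8.5 to 10.1.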

Compound 4, negative logarithm of the antagonist equilibrium constant: 8.9
Compound 4: the middle estimate sits 0.40 log units above what was measured, within the range that was stated.
By their numbers in this assay, from the lowest: compound 1; then compounds 4 and 3 (each within the scatter of the next); then compound 2.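

Pyridin-2-yl does about as well here as 2,5-dimethoxyphenyl in this assay, with a number 0.20 log units lower from compound 3 to compound 4 (within the scatter), so this position accepts a ring with a nitrogen atom and fewer heavy atoms without a change beyond the scatter. A single ring is still not enough to match the best result: a number 0.60 log units higher from compound 1 to compound 4 (beyond the scatter) shows that pyridin-2-yl again beats naphthalen-2-yl, yet a number 1.00 log units lower from compound 2 to compound 4 (beyond the scatter) shows that it falls clearly short of 2-methylphenyl. Nothing available explains these differences.

The compounds shown leave open whether the place of the ring nitrogen matters, which pyridin-3-yl or pyridin-4-yl could test. They also leave open how a plain phenyl ring, or a ring-free group such as a butyl chain, would compare on the sulfonyl sulfur.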